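One Cap Swap, Repeated on a Second Core

The source may hold more compounds than are shown below. What is called first, only, known or untested is meant among the compounds shown, and "the series" means these compounds.

Compound 3 `Cc1ccc(C(=O)Nc2ccc3c(c2)C(F)(F)C[C@H]3N2CCN(C)CC2)cc1C#Cc1cnc(NC2CC2)nc1` is one of three compounds that have been tested in a functional assay on Jurkat cells (Homo sapiens) for inhibition, read by MTT assay, with a stated time of 72 h; a lower number here means a stronger inhibitor, a higher number a weaker inhibitor. There compound 3 gives 400 nM. Compound 1 `Cc1ccc(-c2nc3ccc(N4CCN(C)CC4)cc3[nH]2)cc1C#Cc1cnc(NC2CC2)nc1` gives 292 nM, and compound 2 `Cc1ccc(-c2nc3ccc(N4CCN(C)CC4)cc3[nH]2)cc1C#Cc1cnc2cccnn12` gives 672 nM. On these numbers compound 3 stands second highest of the three, but its value and that of compound 1 lie within the usual scatter of each other, and so do its value and that of compound 2.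

Compound 4 `Cc1ccc(C(=O)Nc2ccc3c(c2)C(F)(F)C[C@H]3N2CCN(C)CC2)cc1C#Cc1cnc2cccnn12` differs from compound 3 in one place: a group of 9 heavy atoms (6 carbon, 3 nitrogen; one five-membered aromatic ring with 2 hetero atoms, one six-membered aromatic ring with 2 hetero atoms) in place of a group of 10 heavy atoms (7 carbon, 3 nitrogen; one three-membered non-aromatic ring of carbon only, one six-membered aromatic ring with 2 hetero atoms), on a triple-bonded carbon. The same swap has been measured once, on the shared core of compound 1 and compound 2: a 2.3-fold higher number from compound 1 to compound 2 (0.36 log units; beyond the scatter). Among the compounds with values here, that single step is the only evidence that bears on the change, and it points to a modest weakening. Compound 4 is therefore expected to give a higher number than compound 3, by about the same amount, a 2.3-fold higher number from compound 3 to compound 4 (0.35 log units; beyond the scatter). For compound 4 the estimate in this assay is 900 nM, with a likely range from 400 nM to 2000 nM.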

Compound 4, half-maximal inhibitory concentration: > 1000 nM
Compound 4 was reported as a limit (the forecaster's own chance of this, stated with the estimate: 3%); middle value at least 1.1-fold (0.04 log units) away from the limit.
By their numbers in this assay, from the lowest: compounds 1, 3 and 2 (each within the scatter of the next, the first and the last beyond it). At a limit, above all of these: compound 4.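

In this assay, putting the two-ring group in place of 2-(cyclopropylamino)pyrimidin-5-yl on the triple-bonded carbon gives an at least 2.5-fold higher number from compound 3 to compound 4 (0.39 log units; beyond the scatter), so the weakening first seen on the core of compound 1 now appears on a second core as well. The reading for compound 4, > 1000 nM, is a limit of the assay and not a number. The change therefore points the same way on both cores, but its size can only be compared loosely: the same change on two cores in this assay, a 2.3-fold higher number (0.36 log units; beyond the scatter) from compound 1 to compound 2 and an at least 2.5-fold higher number (0.39 log units; beyond the scatter) from compound 3 to compound 4; the limit leaves it open whether they differ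

The two groups differ both in their rings and in hydrogen-bond donors, so the compounds shown cannot tell which part of 2-(cyclopropylamino)pyrimidin-5-yl matters. Going by these compounds, a plain amino group or a cyclobutylamino group in place of the cyclopropylamino group could help separate these, and how far compound 4 really lies from compound 3 also stays open.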